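Swapping a Benzoyl for a Phenylsulfonyl on an Acrylonitrile

A few compounds are considered here, and "the series" means these few. Any claim that something is new, unique, unknown or untested is made for them only; others in the source may bear on it.

For the measured compounds named here, compound 1 `N#C/C(=C\c1c(-c2ccccc2)[nH]c2ccccc12)C(=O)c1ccccc1` was tested in a functional assay on Hs-578T cells (Homo sapiens) for inhibition, read by sulforhodamine B assay, with a stated time of 48 h (on this read-out lower numbers stand for stronger inhibition of growth and higher numbers for weaker inhibition of growth), and gave 6300 nM, the higher of the two numbers known so far. Compound 2 `COc1ccc(-c2[nH]c3ccc(OC)cc3c2C=C(C#N)C#N)cc1` gave 513 nM in this assay, a lower number that lies beyond the usual scatter. Compound 3 `N#C/C(=C\c1c(-c2ccccc2)[nH]c2ccccc12)S(=O)(=O)c1ccccc1` has not yet been measured; it differs from compound 1 by phenylsulfonyl in place of benzoyl on a double-bonded chain carbon bound to a double-bonded chain carbon and a triple-bonded carbon. Going by the values given here, no step between measured compounds shows what this change does, so only a cautious expectation is possible. Compound 3 is estimated at 7000 nM (range 2000 nM to 25000 nM), a step of a 1.1-fold higher number from compound 1 to compound 3 (0.05 log units; within the scatter) expected to stay within the scatter.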

Compound 3, concentration for 50% growth inhibition: 23600 nM
Compound 3: the middle estimate sits 3.4-fold (0.53 log units) below what was measured, within the range that was stated.
By their numbers in this assay, from the lowest: compound 2; then compound 1; then compound 3.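

For the compounds shown here, this is the first direct reading of this position: with the rest of the molecule unchanged, phenylsulfonyl in place of benzoyl gives a 3.7-fold higher number from compound 1 to compound 3 (0.57 log units; beyond the scatter) in this assay, which means weaker inhibition of growth. The group at this place therefore matters for this read-out, and of these two, benzoyl gives the lower number. Nothing available explains the step.

As far as these compounds go, whether an amide or a carboxylic acid at this place would beat benzoyl stays open. So does whether the same swap would have a similar effect on the core of compound 2.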